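The source may hold more compounds than are shown below. What is called first, only, known or untested is meant among the compounds shown, and "the series" means these compounds.

Measured compounds in a functional assay on DU-145 cells (Homo sapiens) for antiproliferative activity, read by sulforhodamine B assay, with a stated time of 72 h; a higher number here means a weaker inhibitor, a lower number a stronger inhibitor:
- compound 1 `O=C1CS/C(=N/Nc2nncc3ccccc23)N1c1ccccc1`: 97 nM
- compound 2 `Cc1cc(NS(=O)(=O)c2ccc(Nc3nncc4ccccc34)cc2)no1`: 35 nM

Of the two numbers in hand, compound 2 has the lower one; compound 1 sits higher, and the gap between them is beyond the usual scatter. The two compounds differ in more than one place, so the gap cannot be tied to any single change.

Compound 3 `Cc1cc(C)nc(NS(=O)(=O)c2ccc(Nc3nncc4ccccc34)cc2)n1` is the next compound to be measured. It differs from compound 2 in one place only: 4,6-dimethylpyrimidin-2-yl in place of 5-methyl-1,2-oxazol-3-yl on a sulfonamide nitrogen. Among the compounds with values here, no measured pair shows this change, so its effect is unknown here. The sulfonamide core is kept and both groups carry no donors and the same number of acceptors, so the step from compound 2 to compound 3 is expected to be small, a 1.3-fold higher number from compound 2 to compound 3 (0.11 log units; within the scatter), likely within the scatter in either direction. For compound 3 the estimate in this assay is 45 nM, with a range from 15 nM to 140 nM.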

Compound 3, half-maximal inhibitory concentration: 7.8 nM
The estimate for compound 3 lay 5.8-fold (0.76 log units) above the measured number, outside the stated range (below it).
By their numbers in this assay, from the lowest: compound 3; then compound 2; then compound 1.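

The substituent on the sulfonamide nitrogen is a position that responds in this assay: 4,6-dimethylpyrimidin-2-yl in place of 5-methyl-1,2-oxazol-3-yl gives a 4.5-fold lower number from compound 2 to compound 3 (0.65 log units; beyond the scatter). The earlier compounds shown here differ in more than one place and could tie no gap to this position, whereas this single change moves the number even though the counts of hydrogen-bond donors and acceptors stay the same. Nothing measured on these compounds accounts for the step.

One pair cannot separate the ring size, the two methyl groups and the change in ring hetero atoms, since all of them change together. From the compounds shown here alone, an unsubstituted pyrimidin-2-yl or a phenyl on the same sulfonamide nitrogen would help to tell these apart, and how far this position tolerates an amine or a carboxylic acid remains open.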